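Notes on the amine-side substituent: compound 2 to compound 4

The source may hold more compounds than are shown below. What is called first, only, known or untested is meant among the compounds shown, and "the series" means these compounds.

The shared core is carried by compound 1 `COc1cccc(CNC(=O)c2nc(Br)c3cccnc3c2N[C@H]2CC[C@H](N)CC2)c1`, compound 3 `N[C@H]1CC[C@H](Nc2c(C(=O)NCc3ccco3)nc(Br)c3cccnc23)CC1`, compound 2 `O=C(NCc1ccc(F)cc1)c1nc(Br)c2cccnc2c1NCc1ccccc1` and the unmeasured compound 4 `COC(=O)CNc1c(C(=O)NCc2ccc(F)cc2)nc(Br)c2cccnc12`. In a functional assay on MDA-MB-435 cells (Homo sapiens) for cytotoxicity, read by MTT assay, with a stated time of 72 h (a lower number here means a stronger inhibitor, a higher number a weaker inhibitor), compound 1 gives 7000 nM. For compound 3 only a limit of the assay is known, > 10000 nM. For compound 2 likewise only a limit of the assay is known, > 20000 nM. For the measured compounds named here, the single measured step, an at least 1.4-fold higher number from compound 1 to compound 3 (0.15 log units; that floor lies within the scatter), alters the group on the amide side and does not touch the place changed here. Compound 4 differs from compound 2 by methoxycarbonyl in place of phenyl on a saturated chain carbon bound to a nitrogen on an aromatic ring. Going by the values given here, no measured step bears on this place, so compound 4 is expected to give a step that the limit leaves unreadable from compound 2 to compound 4. Compound 4 is therefore estimated at 25000 nM, between 8000 nM and 80000 nM.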

Compound 4, half-maximal inhibitory concentration: 10000 nM
Compound 4: middle estimate off by 2.5-fold (0.40 log units), on the high side; low and high end bracket the measured number.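

Compound 2 carries only a limit of the assay at this position: the limit of > 20000 nM in this assay, at which 1 of the 4 values shown sits. In this assay compound 4 gives 10000 nM, so this place, with methoxycarbonyl in place of phenyl, now has a readable number. The step is an at least 2.0-fold lower number from compound 2 to compound 4 (0.30 log units; that floor lies within the scatter), which leaves its true size unknown.

As far as these compounds go, whether a carboxylic acid or an amine in place of methoxycarbonyl, or a longer chain, would give a lower number remains open. Compound 1 and compound 4 differ in more than one place, so they cannot be compared.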